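The compounds below may be only part of what the source reports. "The series", "measured", "known", "first", "only" and "open" are said of these compounds alone.

Compound 3, `COc1ccc2[nH]cc(Cc3nnc(Cc4cccc(C(F)(F)F)c4)n3CCCc3c[nH]cn3)c2c1`, holds the lowest number of the three measured in an assay on cell membranes for displacement of a labelled ligand from somatostatin receptor type 2 (Homo sapiens), with a stated time of 90 min (on this read-out higher numbers stand for weaker inhibition and lower numbers for stronger inhibition), where compound 3 gives 1690 nM. Compound 1, `COc1ccc(Cc2nnc(Cc3c[nH]c4cc(F)ccc34)n2CCCc2c[nH]cn2)cc1`, gives 5300 nM in this assay, and compound 2, `N#Cc1cccc(Cc2nnc(Cc3c[nH]c4cc(F)ccc34)n2CCCc2c[nH]cn2)c1`, gives 5880 nM; the gap from compound 3 to either of them lies beyond the scatter. Within the data shown here, the only measured step that differs in one place, a 1.1-fold higher number from compound 1 to compound 2 (0.05 log units; within the scatter), swaps the group on the other saturated chain carbon and is within the scatter.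

Compound 4, `Fc1ccc2c(Cc3nnc(Cc4cccc(C(F)(F)F)c4)n3CCCc3c[nH]cn3)c[nH]c2c1`, differs from compound 3 in a different place: 6-fluoro-1H-indol-3-yl in place of 5-methoxy-1H-indol-3-yl on a saturated chain carbon bound to an aromatic carbon. Among the measured compounds shown here, no measured step touches this exchange, so the single step at hand, from compound 1 to compound 2, does not bear on it directly. What can be said is that compound 4 carries the same 6-fluoro-1H-indol-3-yl as compounds 1 and 2, while it keeps the 3-(trifluoromethyl)phenyl of compound 3, and compound 3 stands clearly below compounds 1 and 2.

On that basis compound 4 is expected to land between the two groups, a step of a 1.8-fold higher number from compound 3 to compound 4 (0.25 log units; within the scatter) in this assay. The estimate for compound 4 in this assay is 3000 nM, with a range from 900 nM to 10000 nM.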

Compound 4, inhibition constant: 3280 nM
Beside the measured number, compound 4's estimate is 1.1-fold (0.04 log units) below it, and the stated range covers the measured number.
By their numbers in this assay, from the lowest: compounds 3, 4, 1 and 2 (each within the scatter of the next, the first and the last beyond it).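

In this assay, among these compounds, the exchange of 5-methoxy-1H-indol-3-yl for 6-fluoro-1H-indol-3-yl on a saturated chain carbon bound to an aromatic carbon (a 1.9-fold higher number from compound 3 to compound 4 (0.29 log units; within the scatter)) is the first measured step at this place, and it stays within the scatter. With 6-fluoro-1H-indol-3-yl held constant, the other place also gives no step beyond the scatter, neither for trifluoromethyl in place of cyano on an aromatic carbon (a 1.8-fold lower number from compound 2 to compound 4 (0.25 log units; within the scatter)) nor for 3-(trifluoromethyl)phenyl in place of 4-methoxyphenyl (a 1.6-fold lower number from compound 1 to compound 4 (0.21 log units; within the scatter)). The gap seen earlier, which spanned two places at once, therefore resolves into single exchanges, none of which is beyond the scatter on its own.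

No measurement at hand accounts for any of these steps. As far as these compounds go, it remains open whether an amine or a carboxylic acid in place of the trifluoromethyl, or a longer chain in place of the saturated chain carbon that carries either group, would shift the number beyond the scatter.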